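The source may hold more compounds than are shown below. What is called first, only, known or untested is meant among the compounds shown, and "the series" means these compounds.

Compound 1 `C[C@H](NC(=O)CC(F)(F)F)c1ccc(NC(=O)[C@H]2C[C@@H]2c2cccnc2)cc1`: 83.7 mL.min-1.g-1
Compound 2 `C[C@H](NC(=O)C1CCOCC1)c1ccc(NC(=O)[C@H]2C[C@@H]2c2cccnc2)cc1`: 25.1 mL.min-1.g-1
Compound 3 `C[C@H](NC(=O)c1ccc(F)cc1)c1ccc(NC(=O)[C@H]2C[C@@H]2c2cccnc2)cc1`: 13.7 mL.min-1.g-1

These numbers come from an ADME assay on microsomes from liver (Mus musculus) for pharmacokinetics; a higher number here means faster removal of the compound, a lower number slower removal. The three compounds share one core and differ only in the group on a carbonyl carbon. Compound 3 stands at the low end of this small set, and the clear gap is to compound 1: a 6.1-fold lower number from compound 1 to compound 3 (0.79 log units; beyond the scatter). Swapping the same 2,2,2-trifluoroethyl for oxan-4-yl also made a modest difference: a 3.3-fold lower number from compound 1 to compound 2 (0.52 log units; beyond the scatter).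

The next compound, compound 4 `C[C@H](NC(=O)c1ncccn1)c1ccc(NC(=O)[C@H]2C[C@@H]2c2cccnc2)cc1`, keeps the core and changes that same place, with pyrimidin-2-yl in place of 4-fluorophenyl on a carbonyl carbon. For the measured compounds named here, no measured step makes this exact swap, and no measured compound carries pyrimidin-2-yl. The closest guide is the swap that ends at 4-fluorophenyl, since it starts from another ring and not from 2,2,2-trifluoroethyl. That step was small: a 1.8-fold lower number from compound 2 to compound 3 (0.26 log units; within the scatter). No step beyond the scatter is therefore expected, although the evidence is thin and the range must stay wide. The estimate means a 1.1-fold lower number from compound 3 to compound 4 (0.06 log units; within the scatter), an expected change that stays within the scatter. Compound 4 is expected at 12 mL.min-1.g-1, with an estimated range of 5 mL.min-1.g-1 to 30 mL.min-1.g-1.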

Compound 4, intrinsic clearance in microsomes: 38.4 mL.min-1.g-1
Beside the measured number, compound 4's estimate is 3.2-fold (0.51 log units) below it, and the stated range ends below it.
By their numbers in this assay, from the lowest: compounds 3, 2 and 4 (each within the scatter of the next, the first and the last beyond it); then compound 1.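

For the compounds shown here, at this place on the carbonyl carbon, one six-membered aromatic ring cannot simply stand in for another in this assay: pyrimidin-2-yl in place of 4-fluorophenyl gives a step beyond the scatter (a 2.8-fold higher number from compound 3 to compound 4 (0.45 log units; beyond the scatter)), which the earlier compounds, with no pyrimidin-2-yl among them, could not show. Pyrimidin-2-yl cannot be told apart from oxan-4-yl (a 1.5-fold higher number from compound 2 to compound 4 (0.18 log units; within the scatter)), yet it still keeps the number under that of the 2,2,2-trifluoroethyl compound (a 2.2-fold lower number from compound 1 to compound 4 (0.34 log units; beyond the scatter)), so all three ring-bearing compounds now lie below compound 1, though by different amounts. Nothing in the data shown explains why the number rises when 4-fluorophenyl leaves and pyrimidin-2-yl enters.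

Two things change at once in this swap, the fluorine leaves and the ring gains nitrogen, so the compounds shown cannot say which of them matters. Plain phenyl would test the loss of fluorine alone and pyridin-2-yl the entry of ring nitrogen, while an open-chain amine on the carbonyl carbon would show whether a ring is needed at all for the lower numbers.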